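The source may report more compounds than this note shows. Statements on the series, on what has been measured and on what is new or still open speak of the compounds shown alone.

In an ADME assay on L929 cells (Mus musculus) for cytotoxicity, read by resazurin assay, with a stated time of 72 h (a lower number here means a stronger inhibitor, a higher number a weaker inhibitor), compound 1 `O=C(/C=C/c1ccc2c(c1)B(O)OC2)c1ccccc1` gives > 10 ug/mL, a limit of the assay. Compound 2 `Cn1cccc1C(=O)/C=C/c1ccc2c(c1)B(O)OC2` gives > 10 ug/mL, again a limit, and so stands at the limit of > 10 ug/mL in this assay, at which 2 of the 2 values shown sit. Compound 3 `Nc1cccc(C(=O)/C=C/c2ccc3c(c2)B(O)OC3)c1` differs from compound 2 by 3-aminophenyl in place of 1-methyl-1H-pyrrol-2-yl on a carbonyl carbon. Among the compounds with values here, the one measured step, a step that the two limits leave unreadable from compound 1 to compound 2, also changes the group on the carbonyl carbon, but it gives no size to carry over. No step beyond the scatter is therefore expected in this assay, in either direction. The expected step is a step that the limit leaves unreadable from compound 2 to compound 3. Compound 3 is estimated at 12 ug/mL, with an expected range of 4 ug/mL to 30 ug/mL.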

Compound 3, half-maximal inhibitory concentration: 10 ug/mL
Estimate against measurement, compound 3: 1.2-fold (0.08 log units) above; the measured number falls inside the stated range.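

In this assay, within the data shown here, compound 3 gives 10 ug/mL as the first value that is a number and not a limit. Compound 1 and compound 2 each stay at a limit of the assay: the limit of > 10 ug/mL in this assay, at which 2 of the 3 values shown sit. 3-aminophenyl in place of 1-methyl-1H-pyrrol-2-yl on a carbonyl carbon gives a number no higher from compound 2 to compound 3 (the limit leaves the size open), and amino in place of hydrogen on an aromatic carbon gives a number no higher from compound 1 to compound 3 (the limit leaves the size open), so neither change has a size yet.

Still open, on these data alone, is whether a hydroxyl or an acetamide in place of amino on that aromatic carbon would give a readable step from compound 3.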